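Enone series: chlorophenyl to isopropylphenyl on the chain arm

The compounds below may be only part of what the source reports. "The series", "measured", "known", "first", "only" and "open" are said of these compounds alone.

For the measured compounds named here, in a functional assay on PC-3 cells (Homo sapiens) for antiproliferative activity, read by MTT assay, with a stated time of 72 h (on this read-out higher numbers stand for weaker inhibition and lower numbers for stronger inhibition), compound 1 `O=C(COc1ccc(C(=O)/C=C/c2ccccc2Cl)cc1)N[C@H]1CCOC1=O` gives 4610 nM, the only numeric value in this set. Compound 2 `CC(C)c1ccc(NCC(=O)N[C@H]2CCOC2=O)cc1` returns only a limit, > 64000 nM. Compound 3 `Cc1cc(Cl)ccc1NCC(=O)N[C@H]1CCOC1=O` likewise returns only a limit, > 64000 nM. Going by the values given here, both of these share the lactone-amide tail of compound 1 but differ from it elsewhere, so the limit of > 64000 nM in this assay, at which 2 of the 3 values shown sit, marks where two of the three compounds sit and leaves compound 1 as the single compound with a measurable number. Compound 4 `CC(C)c1ccc(/C=C/C(=O)c2ccc(OCC(=O)N[C@H]3CCOC3=O)cc2)cc1` differs from compound 1 by 4-isopropylphenyl in place of 2-chlorophenyl on a double-bonded chain carbon bound to a double-bonded chain carbon. Among the compounds with values here, no measured step of this kind exists; compound 2 carries a 4-isopropylphenyl group in a different framework and sits at the limit, which gives no guide for the present change. The step in this assay is expected to be modest, of a size within or near the scatter, with its direction open. Compound 4 is therefore estimated at 5000 nM, within a range of 1500 nM to 20000 nM. The expected step from compound 1 to compound 4 is a 1.1-fold higher number from compound 1 to compound 4 (0.04 log units; within the scatter).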

Compound 4, half-maximal inhibitory concentration: 4660 nM
For compound 4 the middle estimate is 1.1-fold (0.03 log units) above the measured one; the range from low to high includes it.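

At this position, on a double-bonded chain carbon bound to a double-bonded chain carbon, 4-isopropylphenyl in place of 2-chlorophenyl in this assay gives a 1.0-fold higher number from compound 1 to compound 4 (0.00 log units; within the scatter) and so shows that this read-out does not separate the two groups. For the compounds shown here, the earlier compounds held only one number for this enone framework, so the exchange of a chlorine-bearing ring for a larger, all-carbon one had no reading until now. No measurement shown gives a cause for this flat step.

Both the substituent and its place on the ring change in this single step, so the effect of each stays unresolved. As far as these compounds go, whether a polar group on this ring, such as a dimethylamino group or a carboxylic acid, would keep the same level also stays open.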